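Trading a Methoxy for a Methyl on the Aryl Ring

The source may hold more compounds than are shown below. What is called first, only, known or untested is meant among the compounds shown, and "the series" means these compounds.

Of the compounds shown here, three built on one shared core have been tested in a functional assay on C6 cells (Rattus norvegicus) for cytotoxicity, read by MTT assay, with a stated time of 24 h, tested at 12 ug/mL; on this read-out lower numbers stand for a stronger effect and higher numbers for a weaker effect at the one concentration tested. Compound 1 `O=C(CSc1ncccn1)N/N=c1/scc(-c2ccc(F)cc2)n1-c1ccccc1` gives 77.4%, compound 3 `O=C(CSc1nnnn1-c1ccccc1)N/N=c1/scc(-c2ccc(Br)cc2)n1-c1ccccc1` gives 58.6%, and compound 2 `COc1ccc(-c2cs/c(=N/NC(=O)CSc3nnc(C)s3)n2-c2ccccc2)cc1` gives 53.6%, the lowest of the three numbers. Compound 2 lies within the scatter of compound 3, but its gap to compound 1 is beyond the scatter. Compound 4 `Cc1ccc(-c2cs/c(=N/NC(=O)CSc3nnc(C)s3)n2-c2ccccc2)cc1` differs from compound 2 in one place: methyl in place of methoxy on an aromatic carbon. For the measured compounds named here, no pair of measured compounds differs in only one place, so nothing yet shows how far such a small swap moves the read-out in this assay. The expected step is therefore small, a number 2.4 percentage points higher from compound 2 to compound 4 (within the scatter), in no clear direction and not beyond the scatter. Compound 4 is estimated at 56%, with a range from 40% to 72%.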

Compound 4, a percentage reported as activity, at one concentration (the size of the read-out at that concentration, not a potency): 58.3%
The estimate for compound 4 lay 2.3 percentage points below the measured number; measured number inside the range.
By their numbers in this assay, from the lowest: compounds 2, 4 and 3 (each within the scatter of the next); then compound 1.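

This is the first pair shown that differs in only one place: in this assay, the change from 4-methoxyphenyl to 4-methylphenyl gives a number 4.7 percentage points higher from compound 2 to compound 4 (within the scatter). At this position, on an aromatic carbon para to a large group, this small swap therefore leaves the read-out within the usual scatter. Nothing measured here explains that outcome.

An amine, a carboxylic acid or a longer chain at the same place might behave differently. From the compounds shown here alone, whether this swap would give a similar result on compounds with other groups elsewhere also remains open.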